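A few compounds are considered here, and "the series" means these few. Any claim that something is new, unique, unknown or untested is made for them only; others in the source may bear on it.

Measured so far:
Compound 1 `C/C(=N\NC(=O)c1ccc(C(F)(F)F)cc1)c1cnccn1` gives 1160 nM.
Compound 2 `C/C(=N\NC(=O)c1ccc(O)cc1)c1cnccn1` gives 16800 nM.
Compound 3 `O=C(N/N=C/c1ccccn1)c1ccc(O)cc1` gives only a limit, > 80000 nM.

These values come from an ADME assay on cells (Homo sapiens) for antiproliferative activity, read by MTT assay; on this read-out higher numbers stand for weaker inhibition and lower numbers for stronger inhibition. The limit for compound 3 is one of the limits of this assay, (the limit of > 80000 nM in this assay, at which 1 of the 3 values shown sits). Compound 1 and compound 2 share a core and differ in one place: trifluoromethyl in place of hydroxy on an aromatic carbon. That change gives a 14-fold lower number from compound 2 to compound 1 (1.16 log units; beyond the scatter), a large step toward stronger inhibition.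

Compound 4 `O=C(N/N=C/c1ccccn1)c1ccc(C(F)(F)F)cc1` is not yet measured. It stands to compound 3 as compound 1 stands to compound 2: trifluoromethyl in place of hydroxy on an aromatic carbon. The place is the same in both pairs, so this is the same change, though the cores of compound 2 and compound 3 differ and that difference is not broken down here.

The step from compound 3 to compound 4 is expected to be an at least 5.3-fold lower number from compound 3 to compound 4 (0.72 log units; beyond the scatter), similar in direction to a 14-fold lower number from compound 2 to compound 1 (1.16 log units; beyond the scatter), but since compound 3 shows only a limit, the starting point is uncertain. Compound 4 is expected to give about 15000 nM, estimated between 4000 nM and 80000 nM.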

Compound 4, half-maximal inhibitory concentration: 22400 nM
For compound 4 the middle estimate is 1.5-fold (0.17 log units) below the measured one; the measured number falls inside the stated range.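

In this assay, trifluoromethyl in place of hydroxy gives an at least 3.5-fold lower number from compound 3 to compound 4 (0.55 log units; beyond the scatter), so the change goes the same way on both cores shown, though two cores are too few to make a rule for any other core in this series. Compound 3 gives > 80000 nM, which is a limit of the assay. What this does not show is whether the step has the same size on both cores: the same change on two cores in this assay, a 14-fold lower number (1.16 log units; beyond the scatter) from compound 2 to compound 1 and an at least 3.5-fold lower number (0.55 log units; beyond the scatter) from compound 3 to compound 4; the limit leaves it open whether they differ

The compounds shown leave open how other groups on the same aromatic carbon would compare, such as an amine, a carboxylic acid or a longer chain. From the compounds shown here alone, with only hydroxy and trifluoromethyl at that place, it also stays open whether the lower numbers go with the arrival of trifluoromethyl or simply with the loss of hydroxy, a question that a plain hydrogen or a methyl group on each core could help to settle.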